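This account rests on a few compounds, and the source may have more. Where it says the series, first, only, none or still open, it means among the compounds named here.

Measured compounds in a functional assay on MDA-MB-231 cells (Homo sapiens) for cytotoxicity, read by MTT assay; on this read-out lower numbers stand for stronger inhibition and higher numbers for weaker inhibition:
- compound 1 `COc1ccc(-c2cn(-c3ccc(OC)c(O)c3)nn2)cc1`, for which compound 1 gives > 100 nM, a limit of the assay rather than a number.
- compound 2 `COc1ccc(-c2cn(-c3ccc(OC)cc3)nn2)cc1`, for which compound 2 gives > 100 nM, likewise a limit and not a number.

Compound 2 therefore stands only at a limit in this assay, and nothing more precise is known of it. Among the measured compounds shown here, the single measured step, a step that the two limits leave unreadable from compound 1 to compound 2, is one that the two limits leave unreadable; both values sit at the limit of > 100 nM in this assay, at which 2 of the 2 values shown sit. The step now followed leads from compound 2 to compound 3 `COc1ccc(-c2cn(-c3ccc(OC)c(OC)c3)nn2)cc1`, with the change (methoxy in place of hydrogen on an aromatic carbon). No measured step bears on this change in a readable way, so no direction and no size can be drawn from the numbers shown. Compound 3 is thus expected to stay near the limit, with an estimated step that the limit leaves unreadable from compound 2 to compound 3 in this assay. The estimate for compound 3 is 1000 nM, within a range from 100 nM to 30000 nM.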

Compound 3, half-maximal inhibitory concentration: > 10000 nM
Compound 3 was reported as a limit; the forecaster's own chance of this, stated with the estimate: 85%; middle value at least 10-fold (1.00 log units) from the limit.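

Compound 1, compound 2 and compound 3 are all reported only as limits of the assay, so none of the steps among them can be read. The compounds shown leave open how strongly any of the three inhibits in this assay, and whether a hydroxy or methoxy group in that place makes any difference.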